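A few compounds are considered here, and "the series" means these few. Any claim that something is new, unique, unknown or untested is made for them only; others in the source may bear on it.

Measured compounds:
Compound 1 `COc1cc(CNc2nc3cc(N)cc(N)c3nc2-c2ccccc2)cc(OC)c1OC`: in a functional assay on KM12 cells (Homo sapiens) for inhibition, read by sulforhodamine B assay, with a stated time of 48 h (on this read-out lower numbers stand for higher toxicity in this test and higher numbers for lower toxicity in this test), compound 1 shows only a limit, < 50200 nM.
Compound 2 `Nc1cc(N)c2nc(-c3ccccc3)c(Sc3ccc(Cl)c(Cl)c3)nc2c1`: in this assay compound 2 shows only a limit, < 100000 nM.
Compound 3 `COc1ccc(CNc2nc3cc(N)cc(N)c3nc2-c2ccccc2)cc1OC`: in this assay compound 3 gives 72400 nM.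

Among the compounds with values here, compound 3 thus holds the only number in this assay; the other two values are limits. Compound 4 `COc1ccc(CNc2nc3cc(N)cc(N)c3nc2-c2ccccc2)cc1` differs from compound 3 by hydrogen in place of methoxy on an aromatic carbon. One measured step is of the same kind, an at least 1.4-fold higher number from compound 1 to compound 3 (0.15 log units; that floor lies within the scatter), and that floor lies within the scatter, so it fixes neither size nor direction. Within the data shown here, no other step bears on the change. The step of a 1.1-fold higher number from compound 3 to compound 4 (0.04 log units; within the scatter) is therefore expected to stay within the scatter, with no clear direction. Compound 4 is estimated at 80000 nM in this assay, with a range of 35000 nM to 180000 nM.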

Compound 4, concentration lethal to 50% of the cells: < 100000 nM
Compound 4: only a limit was reported (the forecaster's own chance of this, stated with the estimate: 35%); the middle value is on the limit's open side.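

Compound 4 gives only a limit in this assay, < 100000 nM. The step from compound 3 to compound 4 therefore cannot be read. As far as these compounds go, whether going from 3,4-dimethoxyphenyl to 4-methoxyphenyl shifts the number in this assay stays open.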